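The compounds below may be only part of what the source reports. "The series", "measured", "known", "first", "only" and "open" are said of these compounds alone.

Working notes on the series. Among the compounds with values here, compound 1 `CC(Oc1ccc(Oc2ccc(F)cc2)cc1)C(=O)Cn1nnc(-c2ccc(Cl)cc2)n1` is measured in a physicochemical assay for lipophilicity, read by HPLC, tested at 5 mM (a lower number here means a more polar compound, a higher number a more lipophilic compound), and gives 6.2, the highest of the two numbers so far. Compound 2 `CC(Oc1ccc(-c2ccccc2)cc1)C(=O)Cn1nnc(-c2ccc(Cl)cc2)n1` in this assay gives 6.1, and the step of a number 0.10 log units lower from compound 1 to compound 2 (within the scatter) lies within the scatter, so these two compounds are not distinguished by this assay. Compound 3 `COC(=O)c1ccc(-c2nnn(CC(=O)C(C)Oc3ccc(Oc4ccc(F)cc4)cc3)n2)cc1` is not yet measured in this assay. It differs from compound 1 by methoxycarbonyl in place of chloro on an aromatic carbon. Within the data shown here, the one measured step, from compound 1 to compound 2, concerns a different place in the molecule and does not bear on an exchange of chloro; no measured pair covers the change toward compound 3, so the expectation rests on the structural change alone. A step toward lower numbers is expected for compound 3, of about a number 0.70 log units lower from compound 1 to compound 3 (beyond the scatter). Compound 3 is therefore estimated at 5.5, between 5 and 6.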

Compound 3, partition coefficient: 5.4
Compound 3: middle estimate off by 0.10 log units, on the high side, within the range that was stated.
By their numbers in this assay, from the lowest: compound 3; then compounds 2 and 1 (each within the scatter of the next).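

Methoxycarbonyl in place of chloro, on an aromatic carbon para to a large group, gives the first step in this assay that lies beyond the scatter: a number 0.80 log units lower from compound 1 to compound 3 (beyond the scatter). The earlier exchange at the other place, a number 0.10 log units lower from compound 1 to compound 2 (within the scatter), did not separate its two compounds, so this aromatic position is the one place shown where a single change moves the number clearly. No measurement at hand gives a reason for the size of this step.

On these data alone, whether methoxycarbonyl in place of chloro gives a step of similar size on compound 2 remains open. Also open, as far as these compounds go, is where a carboxylic acid or an amine on this same aromatic carbon would fall in this assay relative to compound 3.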